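Extending the triazole nitrogen of compound 2 with a carboxyethyl chain

This account rests on a few compounds, and the source may have more. Where it says the series, first, only, none or still open, it means among the compounds named here.

Of the three compounds measured in an assay on NK92 cells for inhibition of interleukin-15 (Homo sapiens), read by AlphaScreen, with stated times of 30 min and 1 h (a lower number here means a stronger inhibitor, a higher number a weaker inhibitor), compound 2 `Cn1nc(Cc2nnc(SCCCCCCCC(=O)Nc3ccc(Cl)cc3Cl)[nH]2)c2ccccc2c1=O` gives the lowest number, 280 nM. Its nearest neighbour is compound 1 `Cn1nc(Cc2nnc(SCC(=O)Nc3ccc(Cl)cc3Cl)n2CCC=O)c2ccccc2c1=O`, which in this assay gives 4200 nM, a higher number beyond the scatter. Compound 3 `Cn1nc(Cc2nnc(SCC(=O)Nc3ccc(Cl)cc3Cl)n2CCCO)c2ccccc2c1=O` gives only a limit in this assay, > 30000 nM. Within the data shown here, the one step that joins two numbered structures is the move from compound 1 to compound 3, an at least 7.1-fold higher number from compound 1 to compound 3 (0.85 log units; beyond the scatter), and it ends at the limit of > 30000 nM in this assay, at which 1 of the 3 values shown sits, so the weakening it describes is a lower bound only.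

Compound 4 `Cn1nc(Cc2nnc(SCCCCCCCC(=O)Nc3ccc(Cl)cc3Cl)n2CCC(=O)O)c2ccccc2c1=O` differs from compound 2 in one place: 2-carboxyethyl in place of hydrogen on an aromatic nitrogen. Among the measured compounds shown here, the step from compound 1 to compound 3 is the only measured change that touches a chain on that ring nitrogen, and it shows that altering the group there can cost a great deal; in compound 4, however, the chain is added where compound 2 carries a hydrogen, and no measured pair shows hydrogen against any substituent at that nitrogen. The weakening in compound 3 is therefore taken as a caution rather than a template. For compound 4 the expected outcome is a modest rise in number, a 5.4-fold higher number from compound 2 to compound 4 (0.73 log units; beyond the scatter), giving an estimated 1500 nM with a range from 300 nM to 8000 nM.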

Compound 4, half-maximal inhibitory concentration: 9500 nM
The estimate for compound 4 lay 6.3-fold (0.80 log units) below the measured number; the whole stated range lies below it.
By their numbers in this assay, from the lowest: compound 2; then compound 1; then compound 4. At a limit, above all of these: compound 3.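

In this assay, among these compounds, the entry of 2-carboxyethyl in place of hydrogen on the aromatic nitrogen gives a 34-fold higher number from compound 2 to compound 4 (1.53 log units; beyond the scatter), and this is the first measured pair that sets hydrogen against any substituent at this position. It shows that the hydrogen of compound 2 cannot be exchanged for this chain without a large rise in number, even with the long thioether chain of compound 2 kept in place, and unlike the earlier step at this nitrogen, this one has a measured number at both ends, so its full size can be read. The finding rests on this single chain, and nothing among the measurements shown explains the rise.

The compounds shown leave open whether the rise follows from the carboxylic acid at the end of the chain or from the presence of any chain on this nitrogen. A plain methyl or propyl group, a methyl ester or a primary amine on the same position of compound 2 would separate these two readings, and a longer chain ending in the same carboxylic acid would show whether its distance from the ring matters.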